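Glycine analogue of the chloropurine acid amide series

The source may report more compounds than this note shows. Statements on the series, on what has been measured and on what is new or still open speak of the compounds shown alone.

Compound 1 `O=C(O)[C@@H]1CCCN1C(=O)CN(c1nc(Cl)nc2[nH]cnc12)C1CC1`, compound 2 `C[C@@H](O)[C@H](NC(=O)CN(c1nc(Cl)nc2[nH]cnc12)C1CC1)C(=O)O` and compound 3 `CC(C)C[C@H](NC(=O)CN(c1nc(Cl)nc2[nH]cnc12)C1CC1)C(=O)O` share one core and differ only in the acid joined through the amide. In a functional assay on the whole organism (Tail, strain ICR) with Mus musculus as the target, in the tail flick test, with a stated time of 150 min, at a dose of 25 umol/kg by the oral route (a lower number here means a weaker effect, a higher number a stronger effect of the compound at the dose given), compound 1 gives 7.29%, compound 2 gives 24% and compound 3 gives 9.13%. Compound 3 stands second of the three; its gap to compound 1 lies within the scatter, whereas the step of a number 14.9 percentage points lower from compound 2 to compound 3 (beyond the scatter) lies beyond it. The step of a number 16.7 percentage points higher from compound 1 to compound 2 (beyond the scatter) changed the acid altogether. Compound 4 `O=C(O)CNC(=O)CN(c1nc(Cl)nc2[nH]cnc12)C1CC1` arises from compound 3 by hydrogen in place of isobutyl on a saturated chain carbon bound to an amide-type nitrogen and a carbonyl carbon. Among the compounds with values here, no measured step removes a side chain outright; the nearest, the swap of one side chain for another, moved the number only modestly. For compound 4 a step of a number 0.9 percentage points higher from compound 3 to compound 4 (within the scatter) is expected, not beyond the scatter. Compound 4 is estimated at 10%, with a range from 0% to 25%.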

Compound 4, a percentage reported as activity, at one dose (the size of the read-out at that dose, not a potency): 9.08%
The estimate for compound 4 lay 0.9 percentage points above the measured number; low and high end bracket the measured number.
By their numbers in this assay, from the lowest: compounds 1, 4 and 3 (each within the scatter of the next); then compound 2.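

Hydrogen and isobutyl on a saturated chain carbon bound to an amide-type nitrogen and a carbonyl carbon cannot be told apart, with a number 0.1 percentage points lower from compound 3 to compound 4 (within the scatter). Against the same hydrogen, the 1-hydroxyethyl group of compound 2 does differ, with a number 14.9 percentage points lower from compound 2 to compound 4 (beyond the scatter), whereas the 2-carboxypyrrolidin-1-yl acid of compound 1 does not, with a number 1.8 percentage points higher from compound 1 to compound 4 (within the scatter). Nothing available bears on the origin of the 1-hydroxyethyl difference.

Open, going by these compounds, is whether a hydroxymethyl group at this carbon matches 1-hydroxyethyl. On these data alone, the response to an amine or a second carboxylic acid on the side chain is also open.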